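The compounds below may be only part of what the source reports. "The series", "measured", "known", "first", "only" and "open" are said of these compounds alone.

Measured in an assay on isolated protein for inhibition of DNA topoisomerase 1 (Homo sapiens), with a stated time of 15 min; a lower number here means a stronger inhibitor, a higher number a weaker inhibitor:
compound 1 `COc1c(N2CC[C@@H](CN)C2)c(F)cc2c(=O)c(C(=O)O)cn(Cc3ccc(-c4ccccc4)cc3)c12` gives 26000 nM;
compound 2 `COc1c(N2CC[C@@H](CN)C2)c(F)cc2c(=O)c(C(=O)O)cn(Cc3ccc4ccccc4c3)c12` gives 43700 nM;
compound 3 `CNCCCNc1c(F)cc2c(=O)c(C(=O)O)cn(Cc3ccc(-c4ccccc4)cc3)c2c1OC` gives 101000 nM.

Compound 1 holds the lowest number of the three. Its nearest neighbour is compound 2, separated by a 1.7-fold higher number from compound 1 to compound 2 (0.23 log units; within the scatter); that step lies within the scatter, so no order between these two is claimed. The furthest is compound 3, separated by a 3.9-fold higher number from compound 1 to compound 3 (0.59 log units; beyond the scatter), a modest step beyond the scatter.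

Compound 4 `COc1c(N2CC[C@@H](CN)C2)c(F)cc2c(=O)c(C(=O)O)cn(Cc3ccc(-c4ccc(F)cc4)cc3)c12` is not yet measured. Set against compound 1, the change is fluoro in place of hydrogen on an aromatic carbon. Neither measured step bears directly on this change: the step from compound 1 to compound 2 exchanges the whole aryl group on the chain carbon bound to the aromatic nitrogen, and the step from compound 1 to compound 3 alters the amine on the core. Nothing in the measured compounds probes a single fluoro entering on the phenyl of the 4-phenylphenyl group. Absent such a precedent, the expected outcome is no change at the digits printed from compound 1 to compound 4 (within the scatter), that is, no step beyond the scatter in this assay. Compound 4 is therefore estimated at 26000 nM, with a range from 12000 nM to 56000 nM.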

Compound 4, half-maximal inhibitory concentration: 60900 nM
For compound 4 the middle estimate is 2.3-fold (0.37 log units) below the measured one; measured number above the stated range.
By their numbers in this assay, from the lowest: compounds 1, 2, 4 and 3 (each within the scatter of the next, the first and the last beyond it).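

Phenyl to 4-fluorophenyl gives a 2.3-fold higher number from compound 1 to compound 4 (0.37 log units; beyond the scatter) in this assay and so moves the number towards a weaker inhibitor. The earlier steps shown here exchanged the whole aryl group or altered the amine on the core, whereas this change is confined to the phenyl of the 4-phenylphenyl group and shows that one added heavy atom there is enough to take the number beyond the scatter. No measured property in hand accounts for this step.

Going by these compounds, whether the step belongs to fluoro itself or to any group entering at this place stays open, and chloro or nitrile at the same carbon would separate the two. Also open, on these data alone, is whether 4-fluorophenyl would give a similar step with the (3-(methylamino)propyl)amino group of compound 3 on the core.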